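The source may report more compounds than this note shows. Statements on the series, on what has been measured and on what is new or still open speak of the compounds shown alone.

Measured compounds in a functional assay on Bel-7402 cells (Homo sapiens) for antiproliferative activity, read by sulforhodamine B assay, with a stated time of 48 h; on this read-out lower numbers stand for stronger inhibition and higher numbers for weaker inhibition:
- compound 1, `O=C(N/N=C/c1ccccc1O)c1ccc(-c2ccc(F)cc2)o1`: 50300 nM
- compound 2, `COc1ccccc1/C=N/NC(=O)c1ccc(-c2ccc(F)cc2F)o1`: 24600 nM

For the measured compounds named here, compound 2 stands at the lower of the two numbers so far; compound 1 sits beyond the usual scatter above it, but the two differ in two places at once, so no single step can be read from that pair. Compound 3, `O=C(N/N=C/c1ccccc1O)c1ccc(-c2ccc(F)cc2F)o1`, is not yet measured in this assay. Compound 3 differs from compound 2 in one place: hydrogen in place of methyl on an oxygen on an aromatic ring. It keeps the difluorophenyl group of compound 2 and carries the same hydroxyphenyl group that compound 1 bears. Going by the values given here, no measured pair isolates this single change, so its size and direction cannot be taken from the data at hand. The expectation is a step from compound 2 to compound 3 of about a 1.3-fold higher number from compound 2 to compound 3 (0.11 log units; within the scatter) in this assay, that is a modest move, likely within or only just beyond the scatter, toward a somewhat higher number. On that basis, compound 3 is estimated to give 32000 nM in this assay, with a range from 13000 nM to 80000 nM.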

Compound 3, half-maximal inhibitory concentration: 8300 nM
Compound 3: the middle estimate sits 3.9-fold (0.59 log units) above what was measured; measured number outside the range, below it.
By their numbers in this assay, from the lowest: compound 3; then compound 2; then compound 1.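

In this assay, for the compounds shown here, compound 3 carries the first direct reading at this place: with the difluorophenyl group held constant, methoxy to hydroxy on the aromatic ring gives a 3.0-fold lower number from compound 2 to compound 3 (0.47 log units; beyond the scatter) and lies beyond the scatter, so the methyl on this oxygen is not neutral here. With the 2-hydroxyphenyl group held constant, the second single change, fluoro in place of hydrogen on an aromatic carbon, gives a 6.1-fold lower number from compound 1 to compound 3 (0.78 log units; beyond the scatter) and also lies beyond the scatter, which separates the two changes that compound 1 and compound 2 could not resolve as a pair. Nothing available here gives a measured reason for either step.

Whether the methoxy to hydroxy step holds when the phenyl carries a single fluoro stays open, as the compounds shown read that change only on the difluorophenyl group. Also open, going by these compounds, is how other groups at this place would compare with hydroxy and methoxy, such as an amine or a longer chain on the oxygen like ethoxy, since only hydrogen and methyl on this oxygen appear.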